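Sulfonyl aryl swap on two differently joined cores

The source may report more compounds than this note shows. Statements on the series, on what has been measured and on what is new or still open speak of the compounds shown alone.

Compound 1 `Cc1cc(C)cc(S(=O)(=O)c2cnc3cc(F)ccc3c2N2CCC(C)CC2)c1` carries a 3,5-dimethylphenyl on the sulfonyl sulfur; in an assay on isolated protein for displacement of a labelled ligand from metabotropic glutamate receptor 5 (Homo sapiens), with a stated time of 60 min, tested at 1 uM (a lower number here means less inhibition, a higher number more inhibition at the concentration tested (going by the name of the read-out)), compound 1 gives 80%. Compound 2 `CC1CCN(c2c(S(=O)(=O)c3ccc(Cl)cc3)cnc3cc(F)ccc23)CC1` differs from it by 4-chlorophenyl in place of 3,5-dimethylphenyl on a sulfonyl sulfur, and in this assay compound 2 gives 90%; the step is a number 10 percentage points higher from compound 1 to compound 2 (within the scatter). Compound 3 `Cc1cc(C)cc(S(=O)(=O)c2cnc3ccc(F)cc3c2N2CCC(C)CC2)c1` is built from the same atoms as compound 1, joined differently; the difference between the two cores is not broken down here. In this assay compound 3 gives 83%, which lies within the scatter of compound 1. Compound 4 `CC1CCN(c2c(S(=O)(=O)c3ccc(Cl)cc3)cnc3ccc(F)cc23)CC1` has not yet been measured; it stands to compound 3 as compound 2 stands to compound 1, the change being (4-chlorophenyl in place of 3,5-dimethylphenyl on a sulfonyl sulfur). The surroundings of the place read the same in both cases, so this is the same change made a second time. For compound 4 the expected step in this assay is a number 5 percentage points higher from compound 3 to compound 4 (within the scatter), set beside the earlier one, resting on the step of a number 10 percentage points higher from compound 1 to compound 2 (within the scatter) being small and on compound 3 already standing at 83%, which leaves little room upward. Compound 4 is estimated at 88%, between 76% and 97%.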

Compound 4, a percentage reported as inhibition, at one concentration (the size of the read-out at that concentration, not a potency): 80%
Estimate against measurement, compound 4: 8 percentage points above; the measured number falls inside the stated range.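

In this assay, putting 4-chlorophenyl in place of 3,5-dimethylphenyl on the sulfonyl sulfur of the second core gives a number 3 percentage points lower from compound 3 to compound 4 (within the scatter). The two instances of this change do not differ beyond what repeated measurement allows: the same change on two cores in this assay, a number 10 percentage points higher (within the scatter) from compound 1 to compound 2 and a number 3 percentage points lower (within the scatter) from compound 3 to compound 4, 13 percentage points apart, within the scatter of two such steps On both cores the swap leaves the read-out within the scatter, so the pair is consistent with a change that carries across these two cores without a detectable effect, but it shows neither a real gain or loss on either core nor any dependence on the core, and the opposite directions of the two steps carry no weight.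

Within the data shown here, only two aryl groups on the sulfonyl sulfur appear here, both aromatic rings of carbon only, so it stays open whether an aryl bearing an amine or a carboxylic acid would separate the two cores. The read-out in this assay comes from one concentration, which leaves the potency of all four compounds open.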